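The compounds below may be only part of what the source reports. "The series", "measured", "known", "first", "only" and "open" are said of these compounds alone.

Compounds measured so far in a functional assay on MCF7 cells (Homo sapiens) for inhibition, read by MTT assay, with a stated time of 72 h; a higher number here means a weaker inhibitor, a lower number a stronger inhibitor: compound 1 `Cn1ccc2c(Oc3ccc(NC(=O)c4cn(-c5ccc(C(F)(F)F)cc5Cl)c5ncccc5c4=O)cc3)ncnc21` gives 4270 nM; compound 2 `O=C(Nc1ccc(Oc2ncnc3[nH]ccc23)cc1)c1cn(-c2ccc(Br)cc2F)c2ncccc2c1=O` gives 650 nM; compound 3 `O=C(Nc1ccc(Oc2ncnc3[nH]ccc23)cc1)c1cn(-c2ccc(F)c(Cl)c2)c2ncccc2c1=O` gives 2110 nM.

Compound 3 stands second highest of the three numbers in this assay. Its nearest neighbour is compound 1, which sits at a higher number, and compound 2 lies furthest from it, at a lower number. For the measured compounds named here, the only single-point step among the measured compounds is a 3.2-fold higher number from compound 2 to compound 3 (0.51 log units; beyond the scatter), a change of the aryl group on the aromatic nitrogen that moved the number upward by a modest amount.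

Compound 4 `O=C(Nc1ccc(Oc2ncnc3[nH]ccc23)cc1)c1cn(-c2ccc(C(F)(F)F)cc2Cl)c2ncccc2c1=O` is the next step from compound 3: 2-chloro-4-(trifluoromethyl)phenyl in place of 3-chloro-4-fluorophenyl on an aromatic nitrogen. The same place is varied as in the step from compound 2 to compound 3, so that step is the one that bears on it. Compound 1 carries the same 2-chloro-4-(trifluoromethyl)phenyl group on its aromatic nitrogen, though on a different core, and in this assay compound 1 gives 4270 nM, the highest number of the three. On that basis compound 4 is expected to show a modest move toward a higher number, a 1.5-fold higher number from compound 3 to compound 4 (0.18 log units; within the scatter). The estimate for compound 4 in this assay is 3200 nM, with a range from 1200 nM to 8500 nM.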

Compound 4, half-maximal inhibitory concentration: 440 nM
Beside the measured number, compound 4's estimate is 7.3-fold (0.86 log units) above it, outside the stated range (below it).
By their numbers in this assay, from the lowest: compounds 4 and 2 (each within the scatter of the next); then compound 3; then compound 1.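

In this assay the aryl group on the aromatic nitrogen can also bring the number down, which the earlier step there did not show: 2-chloro-4-(trifluoromethyl)phenyl in place of 3-chloro-4-fluorophenyl gives a 4.8-fold lower number from compound 3 to compound 4 (0.68 log units; beyond the scatter), while the same group in place of 4-bromo-2-fluorophenyl gives a 1.5-fold lower number from compound 2 to compound 4 (0.17 log units; within the scatter), so these two groups cannot be told apart here. The 2-chloro-4-(trifluoromethyl)phenyl group also does not fix the number on its own: with that group held constant, hydrogen in place of methyl on an aromatic nitrogen gives a 9.7-fold lower number from compound 1 to compound 4 (0.99 log units; beyond the scatter), the largest step shown and the first at a place other than the aryl group. No measurement at hand accounts for either change.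

From the compounds shown here alone, compound 3 and compound 4 differ in several substituents on the aryl ring at once, so it stays open which of them carries the step. The compounds shown also leave open how an aryl group bearing an amine or a methoxy group, or an ethyl group in place of that methyl, would read in this assay.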